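Compound 1 to compound 3: hydroxy to pyridin-2-yl

This account rests on a few compounds, and the source may have more. Where it says the series, first, only, none or still open, it means among the compounds named here.

In a functional assay on HO8910 cells (Homo sapiens) for inhibition, read by MTT assay, with a stated time of 24 h, tested at 1 ug/mL (on this read-out lower numbers stand for less inhibition of growth and higher numbers for more inhibition of growth at the one concentration tested), compound 1 (`O=C(CCCCC(S)CCS)NO`) is recorded as "not active" (no number reported), without a single number, so it offers no numeric starting point. Going by the values given here, compound 2 (`Cc1cccc(NC(=O)CCCCC(S)CCS)c1`) is the only measured compound with a number, at 2.76%. Compound 3 (`O=C(CCCCC(S)CCS)Nc1ccccn1`) differs from compound 1 by one change on the amide-type nitrogen: pyridin-2-yl in place of hydroxy on an amide-type nitrogen. With compound 1 at "not active" (no number reported) and compound 2 at 2.76%, no step beyond the scatter is expected in this assay in either direction. The expected value for compound 3 is 5%, within an estimated range of 0% to 15%.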

Compound 3, percent growth inhibition at one concentration: "not active" (no number reported)
No number was reported for compound 3; no gap can be computed for the estimate.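

With no number for compound 1 or compound 3 in this assay no step can be read between them, and no evidence at hand bears on the result. Going by these compounds, what pyridin-2-yl in place of hydroxy does to growth inhibition stays open.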